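Swapping the side chain on a thiazole core

A few compounds are considered here, and "the series" means these few. Any claim that something is new, unique, unknown or untested is made for them only; others in the source may bear on it.

Three compounds share one core, carrying two 4-methoxyphenyl groups, and differ only in the side group on the remaining aromatic carbon. Compound 1 `COc1ccc(-c2nc(CNC(=O)N3CCOCC3)sc2-c2ccc(OC)cc2)cc1` carries a (((morpholin-4-yl)carbonyl)amino)methyl group. In a functional assay with Oryctolagus cuniculus as the target (a lower number here means a stronger inhibitor, a higher number a weaker inhibitor), compound 1 gives 660 nM. Within the data shown here, that is the only plain number among the three; the other two are limits of the assay. Compound 2 `CCOC(=O)C1=C(C)N=C(C)/C(=C(/O)OCC)C1c1nc(-c2ccc(OC)cc2)c(-c2ccc(OC)cc2)s1` is reported in this assay only at a limit, < 100 nM, which is the limit of < 100 nM in this assay, at which 1 of the 3 values shown sits. Compound 3 `CCOC(=O)CC(c1nc(-c2ccc(OC)cc2)c(-c2ccc(OC)cc2)s1)N1CCN(C)CC1` is reported in this assay only at a limit, > 1000 nM, which is the limit of > 1000 nM in this assay, at which 1 of the 3 values shown sits. So compound 1 sits between the two limits, and no step between two measured values is available.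

Compound 4 `COc1ccc(-c2nc(C3=NNC(=O)CC3)sc2-c2ccc(OC)cc2)cc1` has not been measured in this assay. It differs from compound 1 in one place: a group of 7 heavy atoms (4 carbon, 2 nitrogen, 1 oxygen; one six-membered non-aromatic ring with 2 hetero atoms) in place of a group of 10 heavy atoms (6 carbon, 2 nitrogen, 2 oxygen; one six-membered non-aromatic ring with 2 hetero atoms), on an aromatic carbon. The two rings entering and leaving are of similar size, and both keep one hydrogen-bond donor and two acceptors.

Among the measured compounds shown here, with no measured step to lean on, the change from compound 1 to compound 4 is expected to stay close to the scatter, with no clear direction. Compound 4 is therefore expected to give about 500 nM in this assay, within a range from 150 nM to 1500 nM, which means an expected step of a 1.3-fold lower number from compound 1 to compound 4 (0.12 log units; within the scatter).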

Compound 4, half-maximal inhibitory concentration: > 1000 nM
Compound 4: no number, only a limit; the forecaster's own chance of this, stated with the estimate: 20%; middle value at least 2.0-fold (0.30 log units) from the limit.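

In this assay compound 4 is reported only as a limit, > 1000 nM. Replacing the (((morpholin-4-yl)carbonyl)amino)methyl group on this aromatic carbon gives an at least 1.5-fold higher number from compound 1 to compound 4 (0.18 log units; that floor lies within the scatter), and this figure is only a floor, so the true step could be larger, but a loss beyond the scatter is not shown. The change adds a new point at this position: a group with a six-membered non-aromatic ring with 2 hetero atoms and the same hydrogen-bond donor and acceptor counts does not bring a plain number back into the measurable range, and the upper end of the read-out now holds a second compound: the limit of > 1000 nM in this assay, at which 2 of the 4 values shown sit.

The compounds shown leave open how far past its limit compound 4 really lies, and so how large this step is. Also open, from the compounds shown here alone, is what a simple amine or a carboxylic acid on this same aromatic carbon would give, and whether a morpholine ring on a longer chain would keep a measurable number.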